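Ring closure at the amide nitrogen substituent

This account rests on a few compounds, and the source may have more. Where it says the series, first, only, none or still open, it means among the compounds named here.

Compound 2 `CC(C)[C@H](NC(=O)c1c(CN2CCC(N3CCCCC3)CC2)c(-c2cccc(C(F)(F)F)c2)nc2ccccc12)c1ccccc1` gives 130 nM in an assay on HEK293 cells for antagonist activity at transient receptor potential cation channel subfamily V member 4 (Homo sapiens), read by FLIPR and calcium flux, with a stated time of 10 min (a higher number here means a weaker inhibitor, a lower number a stronger inhibitor), the lower of the two numbers measured, though the gap to compound 1 `CC[C@H](NC(=O)c1c(CN2CCC(N3CCCCC3)CC2)c(-c2cccc(C(F)(F)F)c2)nc2ccccc12)c1ccccc1` at 160 nM is within the scatter. Compound 3 `O=C(NC1(c2ccccc2)CC1)c1c(CN2CCC(N3CCCCC3)CC2)c(-c2cccc(C(F)(F)F)c2)nc2ccccc12` differs from compound 2 by 1-phenylcyclopropyl in place of 2-methyl-1-phenylpropyl on an amide-type nitrogen. For the measured compounds named here, the only measured step at this position is a 1.2-fold lower number from compound 1 to compound 2 (0.09 log units; within the scatter), which shows that a methyl added on the saturated chain carbon barely moves the number in this assay. The 1-phenylcyclopropyl group is a larger change than any measured step, so no step beyond the scatter is expected, with a modest rise as the more likely side. For compound 3 the estimate is 200 nM, range 80 nM to 500 nM, which is expected to be a 1.5-fold higher number from compound 2 to compound 3 (0.19 log units; within the scatter).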

Compound 3, half-maximal inhibitory concentration: 50 nM
Beside the measured number, compound 3's estimate is 4.0-fold (0.60 log units) above it; measured number outside the range, below it.
By their numbers in this assay, from the lowest: compound 3; then compounds 2 and 1 (each within the scatter of the next).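

Closing the group on the amide-type nitrogen into a cyclopropane ring gives the first change at this position that lies beyond the scatter in this assay, against both open-chain groups (a 2.6-fold lower number from compound 2 to compound 3 (0.41 log units; beyond the scatter); a 3.2-fold lower number from compound 1 to compound 3 (0.51 log units; beyond the scatter)). The step also removes the defined stereocentre of the leaving group, so the ring and the loss of that stereocentre cannot be told apart here. No measurement offered here accounts for the lower number. On these data alone, whether a 1-phenylcyclobutyl group continues this direction remains open, as does the effect of a fluorine on the phenyl ring of 1-phenylcyclopropyl.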